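Dichlorophenyl rearrangement on the sulfonyl group

The compounds below may be only part of what the source reports. "The series", "measured", "known", "first", "only" and "open" are said of these compounds alone.

Compound 2 `CN(C)CCn1cc(S(=O)(=O)c2cc(Cl)cc(Cl)c2)c2cccnc21` gives 28 nM in a functional assay on HeLa cells for agonist activity at 5-hydroxytryptamine receptor 6 (Homo sapiens), read by immunoassay; on this read-out higher numbers stand for an effect only at larger amounts of compound and lower numbers for an effect already at smaller amounts; compound 1 `CN(C)CCn1cc(S(=O)(=O)c2ccccc2)c2cccnc21` gives 25 nM and compound 3 `NCCn1cc(S(=O)(=O)c2cc(Cl)cc(Cl)c2)c2cccnc21` gives 35 nM, and the number of compound 2 lies between these two, all three within the scatter of one another. Compound 4 `CN(C)CCn1cc(S(=O)(=O)c2c(Cl)cccc2Cl)c2cccnc21` differs from compound 2 by 2,6-dichlorophenyl in place of 3,5-dichlorophenyl on a sulfonyl sulfur. Within the data shown here, the one measured step on the sulfonyl substituent, a 1.1-fold higher number from compound 1 to compound 2 (0.05 log units; within the scatter), lies within the scatter; the step of a 1.3-fold higher number from compound 2 to compound 3 (0.10 log units; within the scatter) concerns the chain end and does not bear on this change. Among the measured compounds shown here, no measured pair moves chlorines around the same ring, so the expected step of a 1.3-fold higher number from compound 2 to compound 4 (0.10 log units; within the scatter) is set at no change beyond the scatter, with a widened range for the untested pattern. Compound 4 is therefore estimated at 35 nM, range 10 nM to 120 nM.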

Compound 4, half-maximal effective concentration: 31 nM
Compound 4: middle estimate off by 1.1-fold (0.05 log units), on the high side; measured number inside the range.
By their numbers in this assay, from the lowest: compounds 1, 2, 4 and 3 (each within the scatter of the next).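

In this assay, 2,6-dichlorophenyl in place of 3,5-dichlorophenyl on the sulfonyl sulfur gives a 1.1-fold higher number from compound 2 to compound 4 (0.04 log units; within the scatter), and 2,6-dichlorophenyl in place of phenyl gives a 1.2-fold higher number from compound 1 to compound 4 (0.09 log units; within the scatter). Among these compounds, at this position, a second chlorine pattern now joins phenyl and 3,5-dichlorophenyl with no step beyond the scatter, whereas the earlier compounds offered only one chlorine pattern. No available evidence explains this flat response. From the compounds shown here alone, whether any change on the sulfonyl substituent moves the number beyond the scatter remains open, for instance a methoxy group or a nitrile on the ring, or a pyridine in its place.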